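The compounds below may be only part of what the source reports. "The series", "measured", "known", "first", "only" and "open" are said of these compounds alone.

Working notes on the series. Compound 3 `COc1cc(/C=C/C(=O)c2cccc(NC(=O)c3ccc(Cl)c(Cl)c3)c2)ccc1O` gives 45% in a functional assay on HUVEC cells (Homo sapiens) for inhibition, tested at 10 ug/mL (on this read-out lower numbers stand for a weaker effect and higher numbers for a stronger effect at the one concentration tested), and stands lowest of the three numbers measured: compound 1 `COc1cc(/C=C/C(=O)c2cccc(NC(=O)c3cc(Cl)cc(Cl)c3)c2)ccc1O` gives 58% and compound 2 `COc1cc(/C=C/C(=O)c2cccc(NC(=O)c3ccc(Cl)cc3)c2)ccc1O` gives 66%, both beyond the scatter above compound 3. The step of a number 13 percentage points lower from compound 1 to compound 3 (beyond the scatter) is modest, and the step of a number 21 percentage points lower from compound 2 to compound 3 (beyond the scatter) is the larger one; the step of a number 8 percentage points higher from compound 1 to compound 2 (within the scatter) carries no weight.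

Compound 4 `COc1cc(/C=C/C(=O)c2cccc(NC(=O)c3ccccc3)c2)ccc1O` is the unmeasured member. The change from compound 3 is phenyl in place of 3,4-dichlorophenyl on a carbonyl carbon. The step that bears most directly on it runs the other way: a number 21 percentage points lower from compound 2 to compound 3 (beyond the scatter), so taking a chloro off the ring of compound 3 is expected to raise the number, and compound 4 takes off both. Among the measured compounds shown here, compound 1 also carries two chlorines, yet gives a higher number than compound 3, so the count of chlorines alone does not set the number, and no measured compound carries an unsubstituted phenyl on this carbonyl carbon.

The expectation for compound 4 is a number close to that of compound 2, with a step of a number 17 percentage points higher from compound 3 to compound 4 (beyond the scatter) from compound 3 to compound 4. Compound 4 is estimated at 62%, within 45% to 78%.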

Compound 4, a percentage reported as inhibition, at one concentration (the size of the read-out at that concentration, not a potency): 69%
Beside the measured number, compound 4's estimate is 7 percentage points below it, and the stated range covers the measured number.
By their numbers in this assay, from the lowest: compound 3; then compounds 1, 2 and 4 (each within the scatter of the next, the first and the last beyond it).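

The unsubstituted phenyl gives this carbonyl carbon a reference point in this assay, and both dichlorophenyl groups fall short of it, with a number 24 percentage points higher from compound 3 to compound 4 (beyond the scatter) and a number 11 percentage points higher from compound 1 to compound 4 (beyond the scatter). The 4-chlorophenyl group cannot be told apart from phenyl, with a number 3 percentage points higher from compound 2 to compound 4 (within the scatter), so a single chloro on this ring has no readable cost, and the clear separations from phenyl occur only with two chlorines, although compound 1 still lies within the scatter of compound 2 and the two dichlorophenyl groups therefore do not behave as one simple penalty. Nothing measured alongside these numbers gives a reason for these steps.

As far as these compounds go, the four compounds cover only chloro and hydrogen on this ring, so it remains open how a methoxy group, a carboxylic acid or a dimethylamino group would read here, or whether a cyclohexyl ring could stand in place of the phenyl. With one concentration per compound, the read-out also leaves open whether the separations seen here would hold as differences in potency.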